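Naphthalen-2-yl amide on the methoxy-bearing quinone core

This account rests on a few compounds, and the source may have more. Where it says the series, first, only, none or still open, it means among the compounds named here.

The measured compounds are: compound 1 `CC(C)(CNC(=O)c1ccc2ccccc2c1)CC1=C(O)C(=O)c2ccccc2C1=O`, 28200 nM; compound 2 `COC1=C(CC(C)(C)CNC(=O)c2ccccc2)C(=O)c2ccccc2C1=O`, 61800 nM; compound 3 `COC1=C(CC(C)(C)CNC(=O)c2ccccc2OC)C(=O)c2ccccc2C1=O`, 70700 nM.

In a functional assay on MCF7 cells (Homo sapiens) for cytotoxicity, read by resazurin assay, with a stated time of 3 days (a lower number here means a stronger inhibitor, a higher number a weaker inhibitor), compound 3 gives the highest of the three numbers. Its nearest neighbour is compound 2, and the step of a 1.1-fold higher number from compound 2 to compound 3 (0.06 log units; within the scatter) stays within the scatter. Compound 1 stands furthest away, beyond the scatter, at a lower number.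

Compound 4 `COC1=C(CC(C)(C)CNC(=O)c2ccc3ccccc3c2)C(=O)c2ccccc2C1=O` is the next compound, still to be measured in this assay. It differs from compound 3 in one place: naphthalen-2-yl in place of 2-methoxyphenyl on a carbonyl carbon. Among the compounds with values here, no measured step bears directly on this change. Within the data shown here, the only step available, a 1.1-fold higher number from compound 2 to compound 3 (0.06 log units; within the scatter), concerns the methoxy on the aromatic carbon and was within the scatter. Compound 1 carries the same naphthalen-2-yl amide as compound 4, but on a core that differs from that of compound 4, so its value can only be taken as loose orientation.

Compound 4 is therefore expected to land near the other methoxy-core compounds, with a step of a 1.6-fold lower number from compound 3 to compound 4 (0.20 log units; within the scatter) that may not exceed the scatter, and its estimated value is 45000 nM with a range from 18000 nM to 110000 nM.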

Compound 4, half-maximal inhibitory concentration: 52500 nM
Beside the measured number, compound 4's estimate is 1.2-fold (0.07 log units) below it, within the range that was stated.
By their numbers in this assay, from the lowest: compounds 1, 4, 2 and 3 (each within the scatter of the next, the first and the last beyond it).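

In this assay the aryl group on the carbonyl carbon of the amide proves a weak lever on the shared core: the step of a 1.3-fold lower number from compound 3 to compound 4 (0.13 log units; within the scatter) and the step of a 1.2-fold lower number from compound 2 to compound 4 (0.07 log units; within the scatter) both stay within the scatter, so naphthalen-2-yl, with its second aromatic ring, reads the same as phenyl and 2-methoxyphenyl. The same amide also gives the first direct pairing of the free hydroxyl with its methyl ether, and the step of a 1.9-fold higher number from compound 1 to compound 4 (0.27 log units; within the scatter) stays within the scatter too. No measurement here offers an explanation for these results.

On these data alone, it remains open whether an amine or a carboxylic acid on the aromatic ring, or a saturated cyclohexyl group in its place, would shift the number beyond the scatter. An ethyl group or a longer chain on the oxygen is equally untested by these compounds.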